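Working notes on the carbamoyl replacement in the series

The source may hold more compounds than are shown below. What is called first, only, known or untested is meant among the compounds shown, and "the series" means these compounds.

Three members of the series have been run in an ADME assay on cells (Erythrocyte, Homo sapiens), read by spectrophotometry and hemolysis, with a stated time of 24 h; a lower number here means a stronger inhibitor, a higher number a weaker inhibitor. Compound 1 `CC1(C)[N+]([O-])=c2ccc(COc3ccc(/C=N/NC(=S)Nc4ccccc4)cc3)cc2=[N+]1[O-]` returns only a limit: compound 1 gives < 50 uM, a limit of the assay and not a number. Compound 2 `CC1(C)[N+]([O-])=c2ccc(COc3ccc(/C=N/NC(N)=O)cc3)cc2=[N+]1[O-]` also returns a limit, giving > 200 uM, again not a number. For the measured compounds named here, compound 3 `CC1(C)[N+]([O-])=c2ccc(COc3ccccc3/C=N\NC(=S)Nc3ccccc3)cc2=[N+]1[O-]` is the only member with a measured number; in this assay compound 3 gives 66 uM. Compound 3 has the same atoms as compound 1, joined differently, and the difference between the two cores is not broken down here.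

The change from compound 1 to compound 2 is a group of 3 heavy atoms (1 carbon, 1 nitrogen, 1 oxygen; no ring) in place of a group of 9 heavy atoms (7 carbon, 1 nitrogen, 1 sulfur; one six-membered aromatic ring of carbon only), on an amine nitrogen. It brings an at least 4.0-fold higher number from compound 1 to compound 2 (0.60 log units; beyond the scatter). The size of that step is known only as a floor, since it runs from the limit of < 50 uM in this assay, at which 1 of the 3 values shown sits, to the limit of > 200 uM in this assay, at which 1 of the 3 values shown sits.

Compound 4 `CC1(C)[N+]([O-])=c2ccc(COc3ccccc3/C=N\NC(N)=O)cc2=[N+]1[O-]` is not yet measured in this assay. It stands to compound 3 as compound 2 stands to compound 1: the change is a group of 3 heavy atoms (1 carbon, 1 nitrogen, 1 oxygen; no ring) in place of a group of 9 heavy atoms (7 carbon, 1 nitrogen, 1 sulfur; one six-membered aromatic ring of carbon only), on an amine nitrogen, the same change at the same place. The step from compound 3 to compound 4 is expected to be about a 4.5-fold higher number from compound 3 to compound 4 (0.66 log units; beyond the scatter), because an at least 4.0-fold higher number from compound 1 to compound 2 (0.60 log units; beyond the scatter) was seen for the same change and compound 3 already sits at 66 uM. Compound 4 is therefore estimated at 300 uM in this assay, with a range from 120 uM to 800 uM, and a real chance that only a limit is returned.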

Compound 4, concentration for 50% inhibition: 50 uM
Beside the measured number, compound 4's estimate is 6.0-fold (0.78 log units) above it; measured number outside the range, below it.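

In this assay the carbamoyl replacement gives a 1.3-fold lower number from compound 3 to compound 4 (0.12 log units; within the scatter), so the change on the core of compound 3 does not repeat what was seen on the core of compound 1: the same change on two cores in this assay, an at least 4.0-fold higher number (0.60 log units; beyond the scatter) from compound 1 to compound 2 and a 1.3-fold lower number (0.12 log units; within the scatter) from compound 3 to compound 4, at least 5.2-fold (0.72 log units) apart, beyond the scatter of two such steps
The earlier step runs between two limits of the assay and not between two numbers, so its full size stays unread, and the gap between the two steps is known only as a floor. Within these two pairs the outcome of the change depends on the core, but two pairs do not show what in the cores sets this difference, nor how the change would behave on any further core.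

The change removes the sulfur and the aromatic ring together, so the compounds shown leave open which of the two matters on each core; a urea that keeps the phenyl ring, or a thiosemicarbazone that carries a plain terminal amine in place of the phenylamino group, would separate them. Also open, going by these compounds, is how a small alkyl group such as methyl, or a longer chain, on that amine nitrogen would read on either core.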